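Pyrazin-2-yl in place of 1-(pyridin-2-yl)ethyl: an expected step

The compounds below may be only part of what the source reports. "The series", "measured", "known", "first", "only" and "open" are said of these compounds alone.

Measured values in a functional assay for inhibition, with Homo sapiens as the target (on this read-out higher numbers stand for weaker inhibition and lower numbers for stronger inhibition), for the two compounds so far:

Compound 1 `CC(C)(C)Sc1c(CC(C)(C)C(=O)O)n(Cc2ccc(Cl)cc2)c2ccc(OCc3ccncc3)cc12` gives 6 nM
Compound 2 `C[C@H](COc1ccc2c(c1)c(SC(C)(C)C)c(CC(C)(C)C(=O)O)n2Cc1ccc(Cl)cc1)c1ccccn1` gives 3 nM

Within the data shown here, compound 2 stands within the scatter of compound 1, the only other compound measured, so the two values carry no order. The change to compound 3 `CC(C)(C)Sc1c(CC(C)(C)C(=O)O)n(Cc2ccc(Cl)cc2)c2ccc(OCc3cnccn3)cc12` puts pyrazin-2-yl in place of 1-(pyridin-2-yl)ethyl on a saturated chain carbon bound to an oxygen on an aromatic ring, with pyrazin-2-yl in place of 1-(pyridin-2-yl)ethyl on a saturated chain carbon bound to an oxygen on an aromatic ring as the full count of that exchange.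

Among the measured compounds shown here, one measured step bears on this place, a 2.0-fold lower number from compound 1 to compound 2 (0.30 log units; within the scatter) with 1-(pyridin-2-yl)ethyl in place of pyridin-4-yl, and it stays within the scatter. For the measured compounds named here, no measured compound carries pyrazin-2-yl, so that single step is only a loose guide. With compound 1 at 6 nM and compound 2 at 3 nM despite their different groups here, no step beyond the scatter is expected in this assay for the new group. The estimated step is a 1.7-fold higher number from compound 2 to compound 3 (0.22 log units; within the scatter) and no larger change is expected. For compound 3 the expected value is 5 nM (estimated range 2 nM to 15 nM).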

Compound 3, half-maximal inhibitory concentration: 4 nM
Compound 3: middle estimate off by 1.3-fold (0.10 log units), on the high side; low and high end bracket the measured number.
By their numbers in this assay, from the lowest: compounds 2, 3 and 1 (each within the scatter of the next).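

In this assay the exchange of 1-(pyridin-2-yl)ethyl for pyrazin-2-yl gives a 1.3-fold higher number from compound 2 to compound 3 (0.12 log units; within the scatter) and the exchange of pyridin-4-yl for pyrazin-2-yl gives a 1.5-fold lower number from compound 1 to compound 3 (0.18 log units; within the scatter) so the three compounds carry no order among them. At this place, on a saturated chain carbon bound to an oxygen on an aromatic ring, a six-membered aromatic ring with 2 hetero atoms therefore stands within the scatter of the groups already seen, which the earlier pair could not show. The change from 8 heavy atoms to 6 and the loss of the defined stereocentre also leave no step beyond the scatter in these compounds, and no independent data bear on this result.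

The compounds shown all carry an aromatic ring with nitrogen at this place, so they leave open whether the same holds for a simple amine, a carboxylic acid or a longer saturated chain. They also leave open how the opposite stereocentre of 1-(pyridin-2-yl)ethyl would read in this assay, and which change at this place, if any, would give a step beyond the scatter.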